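Aryl swap on the shared core: compound 3 to compound 4

The source may report more compounds than this note shows. Statements on the series, on what has been measured and on what is new or still open speak of the compounds shown alone.

- compound 1 `C[C@H]1CC[C@@H]2[C@@H](OC(=O)[C@]23CC(c2ccc(F)cc2)N(c2ccccc2)O3)[C@]2(C)C(=O)C=C[C@@]12O` gives 3.35
- compound 2 `Cc1ccccc1C1C[C@@]2(ON1c1ccccc1)C(=O)O[C@@H]1[C@H]2CC[C@H](C)[C@]2(O)C=CC(=O)[C@@]12C` gives 3.64
- compound 3 `C[C@H]1CC[C@@H]2[C@@H](OC(=O)[C@]23CC(c2cccc(Cl)c2)N(c2ccccc2)O3)[C@]2(C)C(=O)C=C[C@@]12O` gives 3.87

In a physicochemical assay for lipophilicity (on this read-out lower numbers stand for lower lipophilicity and higher numbers for higher lipophilicity), compound 3 stands clear of compound 1 alone, with a number 0.52 log units higher from compound 1 to compound 3 (beyond the scatter) and only a number 0.23 log units higher from compound 2 to compound 3 (within the scatter) on the other side.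

Compound 4 `C[C@H]1CC[C@@H]2[C@@H](OC(=O)[C@]23CC(c2ccccc2F)N(c2ccccc2)O3)[C@]2(C)C(=O)C=C[C@@]12O` carries 2-fluorophenyl in place of 3-chlorophenyl on a saturated ring carbon. Within the data shown here, no measured compound holds 2-fluorophenyl. The closest match is compound 1, which holds 4-fluorophenyl where compound 3 holds 3-chlorophenyl, so a number 0.52 log units higher from compound 1 to compound 3 (beyond the scatter) should largely reverse here. Compound 2 adds little, with a number 0.29 log units higher from compound 1 to compound 2 (within the scatter) on swapping 4-fluorophenyl for 2-methylphenyl. In this assay a modest step down is expected, with a number 0.47 log units lower from compound 3 to compound 4 (beyond the scatter) as the estimate for it. The value expected for compound 4 is estimated at 3.4 (range 3.05 to 3.75).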

Compound 4, partition coefficient: 3.35
Compound 4: middle estimate off by 0.05 log units, on the high side; the measured number falls inside the stated range.
By their numbers in this assay, from the lowest: compounds 1, 4, 2 and 3 (each within the scatter of the next, the first and the last beyond it).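

In this assay, 2-fluorophenyl and 4-fluorophenyl on the saturated ring carbon next to the ring nitrogen are not separated (no change at the digits printed from compound 1 to compound 4 (within the scatter)), so the two fluorophenyl groups read alike at this site. The 3-chlorophenyl of compound 3 now stands clear of both fluorophenyl compounds (a number 0.52 log units lower from compound 3 to compound 4 (beyond the scatter)), and this gap no longer rests on compound 1 alone. Compound 2 remains unresolved from its neighbours, with fluoro in place of methyl on an aromatic carbon giving a step within the scatter (a number 0.29 log units lower from compound 2 to compound 4 (within the scatter)).

Nothing among the data offers a reason for these gaps.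

The compounds shown leave open whether the gap from compound 3 follows the chlorine or its ring position, which 3-fluorophenyl and 4-chlorophenyl would separate, and how a phenyl bearing an amine or a carboxylic acid would read here.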